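Trimethoxyphenyl ketone analogue in the cytotoxicity series

This account rests on a few compounds, and the source may have more. Where it says the series, first, only, none or still open, it means among the compounds named here.

Compound 1 `COc1cc(-c2nnc3n2NC(c2ccco2)C(C(=O)c2ccc(C)cc2)S3)cc(OC)c1OC` and compound 2 `COc1cc(-c2nnc3n2NC(c2ccco2)C(C(=O)c2ccc(Cl)cc2)S3)cc(OC)c1OC` share one core and differ only in the aryl ketone. In a functional assay on PC-3 cells (Homo sapiens) for cytotoxicity, read by MTT assay, with a stated time of 48 h (a higher number here means a weaker inhibitor, a lower number a stronger inhibitor), compound 1 gives 7500 nM, while compound 2 gives 67800 nM, the higher of the two numbers; the step of a 9.0-fold higher number from compound 1 to compound 2 (0.96 log units; beyond the scatter) lies beyond the scatter. Compound 3 `COc1cc(C(=O)C2Sc3nnc(-c4cc(OC)c(OC)c(OC)c4)n3NC2c2ccco2)cc(OC)c1OC` carries a further change at the same carbonyl carbon: 3,4,5-trimethoxyphenyl in place of 4-chlorophenyl on a carbonyl carbon. Among the compounds with values here, the only measured step bearing on this position is the one from compound 1 to compound 2, and it shows that the aryl on the carbonyl moves the number well beyond the scatter, without telling the direction for a trimethoxyphenyl. A step of similar size is therefore expected, and the estimate places it toward compound 1, as a 3.4-fold lower number from compound 2 to compound 3 (0.53 log units; beyond the scatter). For compound 3 the expected value in this assay is 20000 nM, with a range from 4000 nM to 100000 nM.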

Compound 3, half-maximal inhibitory concentration: 52200 nM
The estimate for compound 3 lay 2.6-fold (0.42 log units) below the measured number; the range from low to high includes it.
By their numbers in this assay, from the lowest: compound 1; then compounds 3 and 2 (each within the scatter of the next).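

In this assay the exchange of 4-chlorophenyl for 3,4,5-trimethoxyphenyl on the carbonyl carbon gives a 1.3-fold lower number from compound 2 to compound 3 (0.11 log units; within the scatter) and so does not separate the two aryl ketones, even though the entering group brings more heavy atoms and hydrogen-bond acceptors. The same group in place of 4-methylphenyl gives a 7.0-fold higher number from compound 1 to compound 3 (0.84 log units; beyond the scatter) and, with the step from 4-methylphenyl to 4-chlorophenyl, leaves compound 1 as the strongest inhibitor of the three. Nothing available accounts for compound 1 standing apart.

Whether this advantage belongs to the 4-methyl group alone remains open, as only three aryl ketones are shown. Also open, on these data alone, is how an ethyl group or a longer alkyl chain at that ring position, or an amine or a carboxylic acid there, would read in this assay.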